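The compounds below may be only part of what the source reports. "The series", "measured", "known", "first", "only" and "open" are said of these compounds alone.

In a functional assay on aorta for antagonist activity at thromboxane A2 receptor (Rattus norvegicus) (a higher number here means a weaker inhibitor, a lower number a stronger inhibitor), compound 1 `O=C(O)c1ccc2c(c1)CC(CCCCNS(=O)(=O)c1ccc(Cl)cc1)C2` gives only a limit of the assay, > 479 nM, so its place on the scale is known no closer than that bound. Going by the values given here, this is the sole evidence on how compound 1 stands: the limit of > 479 nM in this assay, at which 1 of the 2 values shown sits. Compound 2 `O=C(O)Cc1ccc2c(c1)CC(CCNS(=O)(=O)c1ccc(Cl)cc1)C2`, which bears a carboxymethyl and a shorter chain to the sulfonamide, gives 31.6 nM in this assay. Compound 3 `O=C(O)Cc1ccc2c(c1)CC(CCCCNS(=O)(=O)c1ccc(Cl)cc1)C2` has not yet been measured. It differs from compound 1 in one place: carboxymethyl in place of carboxy on an aromatic carbon. Among the compounds with values here, no measured step joins the two, so the size of the move can only be expected. The step from compound 1 to compound 3 is expected to run toward stronger inhibition, beyond the scatter, an at least 1.9-fold lower number from compound 1 to compound 3 (0.28 log units; that floor lies within the scatter), since compound 2 with the same carboxymethyl gives 31.6 nM. For compound 3 the estimate is 250 nM, within 50 nM to 1500 nM.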

Compound 3, half-maximal inhibitory concentration: 977 nM
Beside the measured number, compound 3's estimate is 3.9-fold (0.59 log units) below it, within the range that was stated.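

Going by these compounds alone, no step from compound 1 to compound 3 can be read in this assay, because compound 1 gives only a limit of the assay: the limit of > 479 nM in this assay, at which 1 of the 3 values shown sits. The compounds shown leave open both the direction and the size of the change when carboxymethyl takes the place of carboxy on an aromatic carbon.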